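Benzyl on the indole nitrogen of a saturated 5-HT4 ketone

This account rests on a few compounds, and the source may have more. Where it says the series, first, only, none or still open, it means among the compounds named here.

Compound 1 `O=C(CCC1CCN(CC2CCCCC2)CC1)c1ccc2[nH]ccc2c1` is measured in an assay for displacement of a labelled ligand from 5-hydroxytryptamine receptor 4 (Homo sapiens), with a stated time of 60 min, tested at 1 uM (on this read-out lower numbers stand for less inhibition and higher numbers for more inhibition at the one concentration tested (going by the name of the read-out)), and gives 100%, a value at which compound 2 `O=C(CCC1CCN(CC2CCCC2)CC1)c1ccc2[nH]ccc2c1` with 100% and compound 3 `COc1c(C(=O)CCC2CCN(CC3CCCCC3)CC2)ccc2[nH]ccc12` with 100% stand level with it. The step of no change at the digits printed from compound 1 to compound 2 (within the scatter) and the step of no change at the digits printed from compound 1 to compound 3 (within the scatter) are both within the scatter. Compound 4 `O=C(CCC1CCN(CC2CCCCC2)CC1)c1ccc2c(ccn2Cc2ccccc2)c1` differs from compound 1 by benzyl in place of hydrogen on an aromatic nitrogen. Neither measured step touches the aromatic nitrogen, so no step here bears directly on this change; because the two shown steps no change at the digits printed from compound 1 to compound 2 (within the scatter) and no change at the digits printed from compound 1 to compound 3 (within the scatter) are flat, the number in this assay stays level across changes elsewhere, but the read-out cannot rise. He therefore expects a step of a number 15 percentage points lower from compound 1 to compound 4 (beyond the scatter) of a modest drop at most, and estimates compound 4 at 85%, ranging from 45% to 100%.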

Compound 4, a percentage reported as inhibition, at one concentration (the size of the read-out at that concentration, not a potency): 42%
Beside the measured number, compound 4's estimate is 43 percentage points above it, and the stated range ends above it.
By their numbers in this assay, from the lowest: compound 4; then compounds 1, 2 and 3 (each within the scatter of the next).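

In this assay, within the data shown here, the aromatic nitrogen of the five-membered aromatic ring is the first place in these compounds where a change moves the read-out: benzyl in place of hydrogen gives a number 58 percentage points lower from compound 1 to compound 4 (beyond the scatter). The earlier steps shown here, at the cyclohexyl group and at an aromatic carbon, stayed within the scatter, so this position does not share their flatness. Nothing available explains the loss. As far as these compounds go, whether methyl or a longer chain on this nitrogen would give a smaller step stays open. So does whether benzyl would cost as much on compound 2 or compound 3.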